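The compounds below may be only part of what the source reports. "The series", "measured", "known", "first", "only" and "open" are said of these compounds alone.

In a functional assay on HepG2 cells (Homo sapiens) for antiproliferative activity, read by CCK-8 assay, with a stated time of 72 h, tested at 8 uM (a higher number here means a stronger effect of the compound at the concentration tested, a lower number a weaker effect), compound 3, `CC(C)n1cnc2c(NCc3ccc(C(=O)Nc4ccccc4N)cc3)nc(Cl)nc21`, gives 74.4%. Compound 2, `CCCCn1cnc2c(NCc3ccc(C(=O)Nc4ccccc4N)cc3)nc(Cl)nc21`, gives 19.6% in this assay. The change from one to the other, (butyl in place of isopropyl on an aromatic nitrogen), made a step of a number 54.8 percentage points lower from compound 3 to compound 2 (beyond the scatter). Compound 1, `CC(C)n1cnc2c(Nc3ccccc3)nc(NCOCc3ccc(/C=C/C(=O)Nc4ccccc4N)cc3)nc21`, gives 40.8% in this assay; how its core differs from the core of compound 3 is not broken down here. Compound 4, `CCCCn1cnc2c(Nc3ccccc3)nc(NCOCc3ccc(/C=C/C(=O)Nc4ccccc4N)cc3)nc21`, has not yet been tested in this assay. It differs from compound 1 by butyl in place of isopropyl on an aromatic nitrogen, the same change that turned compound 3 into compound 2, and the place is described in the same words for both pairs; the change occurs twice among these compounds. On that single precedent, compound 4 is expected to fall below compound 1, since the earlier step was a number 54.8 percentage points lower from compound 3 to compound 2 (beyond the scatter). Compound 1, however, starts from only 40.8%, so there is less room for a fall of equal size. Compound 4 is therefore expected to show a step of a number 22.8 percentage points lower from compound 1 to compound 4 (beyond the scatter). With one example and a different core, the estimate is uncertain. Compound 4 is estimated at 18%, between 5% and 40%.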

Compound 4, a percentage reported as inhibition, at one concentration (the size of the read-out at that concentration, not a potency): 59.3%
Beside the measured number, compound 4's estimate is 41.3 percentage points below it; measured number outside the range, above it.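

In this assay, butyl in place of isopropyl on an aromatic nitrogen gave a step of a number 18.5 percentage points higher from compound 1 to compound 4 (beyond the scatter), so on the core of compound 1 the longer chain did not lower the read-out. Set beside the earlier step, the same change went in opposite directions on the two cores: the same change on two cores in this assay, a number 54.8 percentage points lower (beyond the scatter) from compound 3 to compound 2 and a number 18.5 percentage points higher (beyond the scatter) from compound 1 to compound 4, 73.3 percentage points apart, beyond the scatter of two such steps. For the compounds shown here, this shows that, in this series, the result of the change on one core cannot be carried over to the other, even in direction; it does not show why the two cores part ways, which feature of them decides the outcome, or how the effects would compare at other concentrations, since there are only two pairs, each read at a single concentration.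

The compounds shown leave open which of the several differences between the two cores sets the direction of the step. They also leave open how an ethyl group, a pentyl chain or a cyclopentyl group on the same aromatic nitrogen would read on either core.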